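Swapping furan for thiophene on a long-chain amide

The source may report more compounds than this note shows. Statements on the series, on what has been measured and on what is new or still open speak of the compounds shown alone.

Of the compounds shown here, three sharing one core have been tested in a functional assay on MCF7 cells (Homo sapiens) for cytotoxicity, read by MTT assay, with a stated time of 48 h; a lower number here means a stronger inhibitor, a higher number a weaker inhibitor. Compound 2 `CCCCCCCCCCCCNC(=O)[C@@H](NC(=O)c1ccccc1)[C@@H](C)O` gives 36600 nM. Compound 3 `CCCCCCCCCCCCNC(=O)[C@@H](NC(=O)c1ccco1)[C@@H](C)O` gives 67500 nM, and compound 1 `CCCCCCCCNC(=O)[C@@H](NC(=O)c1cccs1)[C@@H](C)O` gives 72500 nM. Among these three numbers, compound 3 stands second highest; the gap to compound 1 is within the scatter, and so is the gap to compound 2, so no order among the three can be claimed.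

Compound 4 `CCCCCCCCCCCCNC(=O)[C@@H](NC(=O)c1cccs1)[C@@H](C)O` is not yet measured. It differs from compound 3 in one place: thiophen-2-yl in place of furan-2-yl on a carbonyl carbon. Going by the values given here, the one measured step that touches the same place is a 1.8-fold higher number from compound 2 to compound 3 (0.27 log units; within the scatter), which lay within the scatter. Compound 1 carries the same thiophene group as compound 4 but a shorter chain, so its value with the value of compound 3 can only be compared directly, and the two lie close together. Nothing seen here suggests that exchanging one five-membered ring for the other moves the number beyond the scatter, so compound 4 is expected to show a step of a 1.1-fold lower number from compound 3 to compound 4 (0.04 log units; within the scatter), essentially no change. The estimate for compound 4 in this assay is 62000 nM, with a range from 30000 nM to 130000 nM.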

Compound 4, half-maximal inhibitory concentration: 30400 nM
Beside the measured number, compound 4's estimate is 2.0-fold (0.31 log units) above it; the measured number falls inside the stated range.
By their numbers in this assay, from the lowest: compounds 4, 2, 3 and 1 (each within the scatter of the next, the first and the last beyond it).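

In this assay, going by these compounds alone, thiophen-2-yl in place of furan-2-yl on the carbonyl carbon gives the first step at this position that passes beyond the scatter, though only modestly (a 2.2-fold lower number from compound 3 to compound 4 (0.35 log units; beyond the scatter)). The same place now shows that a five-membered ring is not enough to set the outcome, since the two rings with the same count of heavy atoms differ in their numbers, while thiophen-2-yl and phenyl cannot be told apart (a 1.2-fold lower number from compound 2 to compound 4 (0.08 log units; within the scatter)). Within the data shown here, with thiophen-2-yl held fixed, butyl in place of hydrogen on the saturated chain also gives a modest step beyond the scatter (a 2.4-fold lower number from compound 1 to compound 4 (0.38 log units; beyond the scatter)), the first reading of the chain alone, and it is of similar size to the ring exchange.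

The compounds shown leave open whether a pyridine ring on the same carbonyl carbon, or a longer chain on the amide-type nitrogen, would carry these numbers further in either direction. No outside measurement is available to explain either modest step.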